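The source may hold more compounds than are shown below. What is called first, only, known or untested is meant among the compounds shown, and "the series" means these compounds.

In a functional assay on HEK293 cells for positive allosteric modulation of metabotropic glutamate receptor 5 (Rattus norvegicus), read by fluorescence and calcium flux (on this read-out higher numbers stand for larger maximal responses and lower numbers for smaller maximal responses), compound 1 `C[C@@H](NC(=O)c1ccc(C#Cc2ccncc2)cn1)C(C)(C)O` gives 66.6%, compound 2 `C[C@@H](NC(=O)c1ccc(C#CC2CC2)cn1)C(C)(C)O` gives 63.4%, and compound 3 `C[C@@H](NC(=O)c1ccc(C#Cc2cccc(F)n2)cn1)C(C)(C)O` gives 63%, the lowest of the three numbers shown, although a number 3.6 percentage points lower from compound 1 to compound 3 (within the scatter) and a number 0.4 percentage points lower from compound 2 to compound 3 (within the scatter) both lie within the scatter. Compound 4 `C[C@@H](NC(=O)c1ccc(C#Cc2ncccc2F)cn1)C(C)(C)O` has not yet been measured; it differs from compound 3 by 3-fluoropyridin-2-yl in place of 6-fluoropyridin-2-yl on a triple-bonded carbon. Within the data shown here, no measured step exchanges one fluoropyridinyl group for another, so only the two steps into compound 3 bear on this change, and both were within the scatter, as was a number 3.2 percentage points lower from compound 1 to compound 2 (within the scatter). Since every step in the set stays inside the scatter, compound 4 is expected to show no change at the digits printed from compound 3 to compound 4 (within the scatter), nothing beyond the scatter in this assay. Compound 4 is therefore estimated at 63%, between 54% and 72%.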

Compound 4, largest response reached (reported as efficacy), in percent of the reference or control that the assay uses: 60.6%
Compound 4: the middle estimate sits 2.4 percentage points above what was measured, within the range that was stated.
By their numbers in this assay, from the lowest: compounds 4, 3, 2 and 1 (each within the scatter of the next).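

Among these compounds, exchanging 6-fluoropyridin-2-yl for 3-fluoropyridin-2-yl on a triple-bonded carbon, the first exchange between two fluoropyridinyl groups here, gives a number 2.4 percentage points lower from compound 3 to compound 4 (within the scatter) in this assay, so these two groups, with the same atoms joined differently, are not told apart on this read-out. The other two steps, a number 2.8 percentage points lower from compound 2 to compound 4 (within the scatter) and a number 6 percentage points lower from compound 1 to compound 4 (within the scatter), leave pyridin-4-yl, cyclopropyl and 3-fluoropyridin-2-yl likewise unseparated at this place. Nothing available explains why these groups read alike. Still open, from the compounds shown here alone, is whether an amine, a carboxylic acid or a longer alkyl chain on the triple-bonded carbon would shift the maximal response beyond the scatter.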